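This account rests on a few compounds, and the source may have more. Where it says the series, first, only, none or still open, it means among the compounds named here.

Measured compounds:
compound 1, `Oc1ccc(-c2cc(-c3ccsc3)cc(-c3ccccc3O)n2)cc1`, giving 13.8%
compound 2, `Oc1ccc(-c2cc(-c3ccoc3)cc(-c3ccccc3O)n2)cc1`, giving 30.1%

In an assay on isolated protein for inhibition of DNA topoisomerase 1 (Homo sapiens), with a stated time of 30 min, tested at 100 uM (a lower number here means a weaker effect, a higher number a stronger effect of the compound at the concentration tested), compound 2 gives 30.1%, the higher of the two numbers; compound 1 gives 13.8%. Among the compounds with values here, the single measured step between them is a number 16.3 percentage points higher from compound 1 to compound 2 (beyond the scatter).

Compound 3, `Oc1ccc(-c2cc(-c3ccccn3)cc(-c3ccccc3O)n2)cc1`, has not been measured. Its difference from compound 2 is pyridin-2-yl in place of furan-3-yl on an aromatic carbon.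

Within the data shown here, only one measured step bears on this place on the shared core, namely the exchange of one five-membered aromatic ring for another, a number 16.3 percentage points higher from compound 1 to compound 2 (beyond the scatter). Among the measured compounds shown here, no measured step exchanges a five-membered ring for a six-membered one, and nothing shows how a pyridin-2-yl group behaves at this position. For the measured compounds named here, the one step seen is modest, so the account expects no large movement either way for compound 3. The estimated step of a number 8.1 percentage points lower from compound 2 to compound 3 (within the scatter) is expected to lie within the usual scatter. Compound 3 is therefore estimated at 22% in this assay, with a range from 6% to 40%.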

Compound 3, a percentage reported as inhibition, at one concentration (the size of the read-out at that concentration, not a potency): 0.2%
Beside the measured number, compound 3's estimate is 21.8 percentage points above it; the whole stated range lies above it.
By their numbers in this assay, from the lowest: compound 3; then compound 1; then compound 2.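

In this assay the place opposite the ring nitrogen tolerates far less than the exchange between five-membered rings suggested, for pyridin-2-yl in place of furan-3-yl gives a number 29.9 percentage points lower from compound 2 to compound 3 (beyond the scatter) and pyridin-2-yl in place of thiophen-3-yl gives a number 13.6 percentage points lower from compound 1 to compound 3 (beyond the scatter) on the same shared core. Both steps run in the same direction and both lie beyond the scatter, so the order among the three compounds is no longer set by the five-membered rings alone. The compound with the one six-membered ring stands below both compounds with a five-membered ring, and compound 3 gives 0.2% at the tested concentration, a read-out close to no inhibition at all.

The compounds shown do not tell whether this low number belongs to six-membered rings at this place in general or to pyridin-2-yl alone: a plain phenyl, a pyridin-3-yl or a pyridin-4-yl group, or an amine, is not among them. Nothing given here accounts for the drop itself.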